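The compounds below may be only part of what the source reports. "The series", "measured", "known", "first", "only" and "open" are said of these compounds alone.

Measured so far in a physicochemical assay for lipophilicity; a higher number here means a more lipophilic compound, a lower number a more polar compound:
compound 1 `Cc1nc(-c2cc(C(F)(F)F)ccc2[C@H]2CCOc3cc(S(=O)(=O)Nc4cccc(F)n4)ccc32)co1`: 4
compound 2 `O=S(=O)(Nc1nccs1)c1ccc2c(c1)OCC[C@H]2c1ccc(C(F)(F)F)cc1-c1nccs1`: 3.3
compound 3 `O=C1OCCN1c1cc(C(F)(F)F)ccc1[C@H]1CCOc2cc(S(=O)(=O)Nc3nccs3)ccc21`: 2.1

Compound 2 stands second highest of these three. Compound 1 lies above it and compound 3 lies further off below it, both gaps beyond the usual scatter. Compound 4 `Cc1nc(-c2cc(C(F)(F)F)ccc2[C@@H]2CCOc3cc(S(=O)(=O)Nc4nccs4)ccc32)co1` awaits measurement. It differs from compound 2 in one place, with 2-methyl-1,3-oxazol-4-yl in place of 1,3-thiazol-2-yl on an aromatic carbon. Going by the values given here, no measured pair shows this change alone. Compound 1 also carries 2-methyl-1,3-oxazol-4-yl and gives 4, but it differs from compound 2 elsewhere too, which makes it only a weak guide. A slight rise in this assay, none beyond the scatter, is expected, with an estimated step of a number 0.10 log units higher from compound 2 to compound 4 (within the scatter). Compound 4 is expected at 3.4, with an estimated range from 2.9 to 3.9.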

Compound 4, distribution coefficient: 2.9
Compound 4: middle estimate off by 0.50 log units, on the high side; the measured number falls inside the stated range.
By their numbers in this assay, from the lowest: compound 3; then compound 4; then compound 2; then compound 1.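

In this assay the exchange of 1,3-thiazol-2-yl for 2-methyl-1,3-oxazol-4-yl gives a number 0.40 log units lower from compound 2 to compound 4 (beyond the scatter) and so shows this change on its own. At this aromatic carbon, ortho to a large group, the group with more heavy atoms gives the lower number, although the counts of hydrogen-bond donors and acceptors stay the same. No measurement shown here explains this step.

As far as these compounds go, what an amine or a methoxy group on this same carbon would give remains open. So does whether this exchange gives a similar step when the rest of the molecule differs.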